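Butyl to cyclopropyl on the amine of compound 2

This account rests on a few compounds, and the source may have more. Where it says the series, first, only, none or still open, it means among the compounds named here.

Among the measured compounds shown here, compound 2 `CCCCNc1nc(-c2ccccc2)nc2c1nnn2Cc1ccccc1C(F)(F)F` gives 6.5 nM in an assay on Cerebral cortex for displacement of a labelled ligand from adenosine receptor A1 (Bos taurus) (on this read-out lower numbers stand for stronger inhibition and higher numbers for weaker inhibition), nominally the higher of the two numbers so far but within the scatter of compound 1 `CCCCNc1nc(-c2ccccc2)nc2c1nnn2Cc1ccccc1F`, which gives 4.3 nM. For the measured compounds named here, the only measured step, a 1.5-fold higher number from compound 1 to compound 2 (0.18 log units; within the scatter), concerns the aromatic substituent and not the amine. Compound 3 `FC(F)(F)c1ccccc1Cn1nnc2c(NC3CC3)nc(-c3ccccc3)nc21` differs from compound 2 by cyclopropyl in place of butyl on a nitrogen on an aromatic ring. Going by the values given here, no measured step bears on this change, so its direction is open. As a working guess a small step, a 1.2-fold higher number from compound 2 to compound 3 (0.09 log units; within the scatter), is expected. Compound 3 is therefore estimated at 8 nM, within 2 nM to 35 nM.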

Compound 3, inhibition constant: 7.8 nM
The estimate for compound 3 lay 1.0-fold (0.01 log units) above the measured number, and the stated range covers the measured number.
By their numbers in this assay, from the lowest: compounds 1, 2 and 3 (each within the scatter of the next).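

In this assay, cyclopropyl in place of butyl on a nitrogen on an aromatic ring gives a 1.2-fold higher number from compound 2 to compound 3 (0.08 log units; within the scatter), the first step read at this amine, as the earlier step concerned only the aromatic substituent. An open chain and a three-membered ring on this nitrogen therefore cannot be told apart on this read-out. Nothing available explains this result.

Still open, from the compounds shown here alone, is how a longer chain, a cyclohexyl ring or a plain amino group would read at this position. Going by these compounds, it is also open whether the same exchange reads alike with the fluoro substituent of compound 1.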